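Shortening the Aryl Chain on a Triazole Lactone

This account rests on a few compounds, and the source may have more. Where it says the series, first, only, none or still open, it means among the compounds named here.

Measured so far, in a functional assay on SW-620 cells (Homo sapiens) for antiproliferative activity, read by MTT assay, with a stated time of 72 h; a lower number here means a stronger inhibitor, a higher number a weaker inhibitor:
Compound 1, `O=C1O/C(=C\Cn2cc(-c3ccc(Br)cc3)nn2)C(OCc2ccccc2)=C1OCc1ccccc1`: compound 1 gives only a limit of the assay, > 100000 nM.
Compound 2, `O=C1O[C@H]([C@@H](O)Cn2cc(-c3cc(C(F)(F)F)cc(C(F)(F)F)c3)nn2)C(OCc2ccccc2)=C1OCc1ccccc1`: compound 2 gives 49200 nM.
Compound 3, `CCCCCc1ccc(-c2cn(C[C@H](O)[C@H]3OC(=O)C(OCc4ccccc4)=C3OCc3ccccc3)nn2)cc1`: compound 3 gives 12200 nM.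

Three compounds share one core, a lactone carrying two benzyloxy groups, and differ in the triazole-linked aryl piece and in the side chain that joins it. Of the two real numbers in this assay, compound 3 holds the lowest; compound 2 sits at a higher number, and that gap lies beyond the usual scatter of repeated measurements. Compound 1 is known only as a limit, as recorded in the limit of > 100000 nM in this assay, at which 1 of the 3 values shown sits, so it cannot be ranked against the others.

Compound 4, `Cc1ccc(-c2cn(C[C@H](O)[C@H]3OC(=O)C(OCc4ccccc4)=C3OCc3ccccc3)nn2)cc1`, is the next member. Relative to compound 3 it carries hydrogen in place of butyl on a saturated chain carbon bound to an aromatic carbon, so the pentyl chain on the aryl ring shrinks to a methyl group. Within the data shown here, no measured pair in this set makes such a change, so its effect has to be guessed. The expectation is a step toward a higher number, beyond the scatter, of about a 2.9-fold higher number from compound 3 to compound 4 (0.46 log units; beyond the scatter). Compound 4 is therefore estimated at 35000 nM, within a range from 12000 nM to 100000 nM.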

Compound 4, half-maximal inhibitory concentration: > 100000 nM
Compound 4 was reported as a limit; the forecaster's own chance of this, stated with the estimate: 20%; middle value at least 2.8-fold (0.45 log units) from the limit.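

The pentyl chain turns out to matter at this spot: changing 4-pentylphenyl to 4-methylphenyl, with hydrogen in place of butyl on a saturated chain carbon bound to an aromatic carbon, gives an at least 8.1-fold higher number from compound 3 to compound 4 (0.91 log units; beyond the scatter) in this assay. The earlier compounds shown here could not show this, since they differ from one another in more than one place, whereas this pair isolates a single change and ties the lower number of compound 3 to the four carbons that leave. Compound 4 gives > 100000 nM, which is a limit of the assay, so the step sets only a floor on the size of the change and its full size cannot be read: the limit of > 100000 nM in this assay, at which 2 of the 4 values shown sit.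

The compounds shown leave open how the number moves along the series between methyl and pentyl, for instance with a propyl group, and whether a longer chain such as octyl would lower it further. They also leave open whether the chain itself is what counts or whether a pentyl chain ending in an amine or a carboxylic acid would keep the number of compound 3.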